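Moving Two Chlorines Around a Benzamide Ring

The source may hold more compounds than are shown below. What is called first, only, known or untested is meant among the compounds shown, and "the series" means these compounds.

Of the compounds shown here, two built on a shared core have been measured in an assay on isolated protein for inhibition of sodium- and chloride-dependent glycine transporter 1 (Homo sapiens); on this read-out higher numbers stand for weaker inhibition and lower numbers for stronger inhibition. Compound 1, `Cn1cnc(S(=O)(=O)N2C[C@@H]3[C@H](C2)[C@@]3(CNC(=O)c2cc(Cl)cc(Cl)c2)CC2CC2)c1`, gives 100 nM, the lower of the two numbers seen so far. Compound 2, `O=C(NC[C@]1(CC2CC2)[C@@H]2CN(S(=O)(=O)c3cccnc3)C[C@@H]21)c1ccc(Cl)cc1Cl`, differs from compound 1 in more than one place; in this assay compound 2 gives 890 nM, a gap that lies well beyond the usual scatter of repeated measurements. Compound 3, `Cn1cnc(S(=O)(=O)N2C[C@@H]3[C@H](C2)[C@@]3(CNC(=O)c2c(Cl)cccc2Cl)CC2CC2)c1`, has not yet been measured. It keeps the same atoms as compound 1 but joins them differently: 2,6-dichlorophenyl in place of 3,5-dichlorophenyl on a carbonyl carbon. Only the positions of the two chlorines on the benzamide ring move. Among the measured compounds shown here, no measured pair here isolates such a rearrangement, so its effect is not known from these data. The step from compound 1 to compound 3 is expected to be a 3.0-fold higher number from compound 1 to compound 3 (0.48 log units; beyond the scatter), a modest loss of inhibition, somewhat beyond the scatter, with real uncertainty in either direction. Compound 3 is therefore estimated to give 300 nM in this assay, most likely between 80 nM and 1200 nM.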

Compound 3, half-maximal inhibitory concentration: 28 nM
Compound 3: middle estimate off by 11-fold (1.03 log units), on the high side, outside the stated range (below it).
By their numbers in this assay, from the lowest: compound 3; then compound 1; then compound 2.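

In this assay, rearranging 3,5-dichlorophenyl into 2,6-dichlorophenyl on the carbonyl carbon gives a 3.6-fold lower number from compound 1 to compound 3 (0.55 log units; beyond the scatter). The atoms stay the same and only their arrangement changes, so this pair shows that where the two chlorines sit on the benzamide ring can by itself shift the reading by more than the usual scatter, and here the shift is towards stronger inhibition. Among the compounds shown here, this is the first comparison in the set that isolates one change, but it shows only what happens on the core of compound 1, and nothing available explains the gain.

Whether both chlorines are needed remains open, as does whether other groups could fill their role, since a benzamide ring with a single chlorine, two fluorines or two methyl groups does not appear among these compounds. It is also unknown whether moving the chlorines to the 2,6-dichlorophenyl arrangement would bring a similar gain with the different group on the sulfonyl of compound 2, because that compound differs from the others in more than one place.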